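Amino in Place of Bromo: What to Expect for Compound 4

The compounds below may be only part of what the source reports. "The series", "measured", "known", "first", "only" and "open" are said of these compounds alone.

compound 1 `Fc1cccc(-c2nc(Nc3ccc(Cl)cc3)c3cc(F)ccc3n2)c1` — 38400 nM
compound 2 `Fc1cccc(-c2nc(Nc3ccccc3Cl)c3cc(F)ccc3n2)c1` — > 50000 nM
compound 3 `Fc1cccc(-c2nc(Nc3ccccc3Br)c3cc(F)ccc3n2)c1` — > 50000 nM

The three measured compounds were tested in a functional assay on U2OS cells (Homo sapiens) for cytotoxicity, read by MTT assay, with a stated time of 48 h; a lower number here means a stronger inhibitor, a higher number a weaker inhibitor. Compound 1 gives 38400 nM. Compound 2 reaches only the limit of the assay, > 50000 nM. Compound 3 likewise stands at the assay limit, > 50000 nM, so no number is known for it; two of the three values sit at that limit (the limit of > 50000 nM in this assay, at which 2 of the 3 values shown sit). The step of an at least 1.3-fold higher number from compound 1 to compound 2 (0.11 log units; that floor lies within the scatter) and the step of an at least 1.3-fold higher number from compound 1 to compound 3 (0.11 log units; that floor lies within the scatter) are both floors that lie within the scatter, and the step that the two limits leave unreadable from compound 2 to compound 3 cannot be read from two limits. Compound 4 `Nc1ccccc1Nc1nc(-c2cccc(F)c2)nc2ccc(F)cc12` differs from compound 3 in one place: amino in place of bromo on an aromatic carbon. Within the data shown here, none of the measured steps involves an amino group, so they bear on this change only by showing that every measured compound sits at the assay limit or close to it. Compound 4 is therefore expected to give about 50000 nM, within the range 15000 nM to 150000 nM. The expected step of a number no higher from compound 3 to compound 4 (the limit leaves the size open) is uncertain, and a limit rather than a number is the likelier report.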

Compound 4, half-maximal inhibitory concentration: 37900 nM
The estimate for compound 4 lay 1.3-fold (0.12 log units) above the measured number, within the range that was stated.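

In this assay, among these compounds, compound 4 is the first compound with a group on this aromatic carbon, ortho to a large group, to return a number rather than a limit. Amino in place of bromo gives an at least 1.3-fold lower number from compound 3 to compound 4 (0.12 log units; that floor lies within the scatter), and amino in place of chloro gives an at least 1.3-fold lower number from compound 2 to compound 4 (0.12 log units; that floor lies within the scatter); both are only floors within the scatter, and their true size cannot be read because the bromo and chloro compounds stand at a limit: the limit of > 50000 nM in this assay, at which 2 of the 4 values shown sit. Set against the 4-chlorophenyl compound, the 2-aminophenyl compound gives a 1.0-fold lower number from compound 1 to compound 4 (0.01 log units; within the scatter), so the two cannot be told apart.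

The step between the chloro and bromo compounds cannot be read. As far as these compounds go, whether a hydroxy or a methylamino group on this same carbon would give a number like amino, or a limit like bromo and chloro, stays open.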